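The compounds below may be only part of what the source reports. "The series", "measured", "known", "first", "only" and "open" are said of these compounds alone.

- compound 1 `CC(=O)N1CC2(CC(=O)c3cc(/C=C/C(=O)NO)ccc3O2)C1`: 15100 nM
- compound 2 `CCOC(=O)N1CC2(CC(=O)c3cc(/C=C/C(=O)NO)ccc3O2)C1`: 1880 nM

Both values come from a functional assay on K562 cells (Homo sapiens) for antiproliferative activity, read by luminescence, with a stated time of 72 h; on this read-out higher numbers stand for weaker inhibition and lower numbers for stronger inhibition. Compound 2 has the lower of the two numbers, which makes it the stronger inhibitor of this pair. Compound 3 `O=C(/C=C/c1ccc2c(c1)C(=O)CC1(CN(Cc3ccccc3)C1)O2)NO` keeps the shared core but has benzyl in place of ethoxycarbonyl on an amine nitrogen in a ring. Among the compounds with values here, only one measured step bears on this change: an 8.0-fold lower number from compound 1 to compound 2 (0.90 log units; beyond the scatter). That step shows that the read-out can move beyond the scatter when this substituent is altered. However, both of its compounds keep a carbonyl, and no measured compound carries benzyl, so the evidence for direction is weak. A modest shift towards stronger inhibition is expected, though a shift the other way cannot be excluded. The expected change is a 1.9-fold lower number from compound 2 to compound 3 (0.27 log units; within the scatter). For compound 3 the estimated value is 1000 nM, with an expected range of 300 nM to 3500 nM.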

Compound 3, half-maximal inhibitory concentration: 175 nM
Compound 3: middle estimate off by 5.7-fold (0.76 log units), on the high side; the measured number lies below the stated range.
By their numbers in this assay, from the lowest: compound 3; then compound 2; then compound 1.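

In this assay benzyl on the amine nitrogen in a ring gives an 11-fold lower number from compound 2 to compound 3 (1.03 log units; beyond the scatter) and also an 86-fold lower number from compound 1 to compound 3 (1.94 log units; beyond the scatter) so it outdoes both groups that attach through a carbonyl. Within the data shown here, the earlier pair showed only that exchanging one carbonyl-linked group for another moves the number, whereas compound 3 shows that a group with no carbonyl, carrying a six-membered aromatic ring of carbon only, gives the lowest number of the three at this position. No measurement shown here explains this gain.

The compounds shown do not separate the effect of adding the aromatic ring from that of losing the carbonyl, a question that a plain ethyl group on this nitrogen could address. As far as these compounds go, how a fluorobenzyl group or the longer phenethyl chain would compare also remains open.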